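This account rests on a few compounds, and the source may have more. Where it says the series, first, only, none or still open, it means among the compounds named here.

Compound 1 `C=CC[C@H]1C[C@]2([C@@H](C)Cc3ccc(OC)c(NC(C)=O)c3)OCOC2=CC1=O`: 310 nM in a functional assay on NCI-H460 cells (Homo sapiens) for antiproliferative activity, with a stated time of 72 h; on this read-out higher numbers stand for weaker inhibition and lower numbers for stronger inhibition
Compound 2 `C=CC[C@H]1C[C@]2([C@@H](C)Cc3ccc(OC)c(F)c3)OCOC2=CC1=O`: 90 nM in this assay

Among the measured compounds shown here, on these numbers compound 1 stands highest of the two, the only measured step being a 3.4-fold lower number from compound 1 to compound 2 (0.54 log units; beyond the scatter). Compound 3 `C=CC[C@H]1C[C@]2([C@@H](C)Cc3cc(NC(C)=O)c(OC)cc3F)OCOC2=CC1=O` differs from compound 1 by fluoro in place of hydrogen on an aromatic carbon. That one measured step also brought fluorine in, but it removed the acetamido group at the same time, so it bears only loosely on the present change, where the acetamido group stays. A small step in this assay, downward or none beyond the scatter, is therefore expected for compound 3. The estimate for compound 3 is 200 nM, between 80 nM and 500 nM. This would mean an expected step of a 1.6-fold lower number from compound 1 to compound 3 (0.19 log units; within the scatter).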

Compound 3, half-maximal inhibitory concentration: 71 nM
The estimate for compound 3 lay 2.8-fold (0.45 log units) above the measured number; the whole stated range lies above it.
By their numbers in this assay, from the lowest: compounds 3 and 2 (each within the scatter of the next); then compound 1.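

Fluoro in place of hydrogen on this aromatic carbon, ortho to a large group and para to an acetamido group, gives a 4.4-fold lower number from compound 1 to compound 3 (0.64 log units; beyond the scatter) in this assay. The earlier step replaced the acetamido group itself, whereas this one shows that, with the acetamido group kept, a single fluoro at this place moves the number beyond the scatter. No measurement at hand explains this step.

Going by these compounds, whether chloro, methyl or an amine on this carbon would give a similar step stays open. So does whether fluoro here would do the same in compound 2.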